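Extending a Side Chain on Two Related Cores

The source may report more compounds than this note shows. Statements on the series, on what has been measured and on what is new or still open speak of the compounds shown alone.

Of the compounds shown here, three have been measured in a functional assay on HL-60 cells (Homo sapiens) for cytotoxicity, read by WST assay, with a stated time of 48 h; on this read-out lower numbers stand for an effect already at smaller amounts and higher numbers for an effect only at larger amounts of compound. Compound 1 `CCc1ccc(C[C@H]2COC(=O)[C@@H]2Cc2ccc(Cl)c(Cl)c2)cc1` gives 16000 nM in this assay. Compound 2 `CCCCc1ccc(C[C@H]2COC(=O)[C@@H]2Cc2ccc(Cl)c(Cl)c2)cc1` differs from compound 1 in a single place, (ethyl in place of hydrogen on a saturated chain carbon, two bonds along the chain from an aromatic carbon), and in this assay compound 2 gives 9400 nM. The step between them is a 1.7-fold lower number from compound 1 to compound 2 (0.23 log units; within the scatter). Compound 3 `CCc1ccc(C[C@H]2COC[C@@H]2Cc2ccc(Cl)c(Cl)c2)cc1` carries a different core; the difference between the two cores is not broken down here. In this assay compound 3 gives 26000 nM, a number whose distance from compound 1 lies within the scatter and whose distance from compound 2 lies beyond it.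

Compound 4 `CCCCc1ccc(C[C@H]2COC[C@@H]2Cc2ccc(Cl)c(Cl)c2)cc1` has not yet been measured. It stands to compound 3 exactly as compound 2 stands to compound 1: ethyl in place of hydrogen on a saturated chain carbon, two bonds along the chain from an aromatic carbon. This same change therefore occurs twice among the compounds shown, once measured and once not. Since the measured occurrence moved the number only a little, the step from compound 3 to compound 4 is expected to be of a similar size, a 1.7-fold lower number from compound 3 to compound 4 (0.24 log units; within the scatter), resting on the single earlier occurrence a 1.7-fold lower number from compound 1 to compound 2 (0.23 log units; within the scatter). Compound 4 is thus estimated at 15000 nM in this assay, within a range from 7000 nM to 32000 nM.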

Compound 4, half-maximal effective concentration: 23000 nM
The estimate for compound 4 lay 1.5-fold (0.19 log units) below the measured number, within the range that was stated.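

The change from ethyl to butyl gives a 1.1-fold lower number from compound 3 to compound 4 (0.05 log units; within the scatter) in this assay. Set beside the same change on the other core, the new step shows no difference that can be told from the scatter: the same change on two cores in this assay, a 1.7-fold lower number (0.23 log units; within the scatter) from compound 1 to compound 2 and a 1.1-fold lower number (0.05 log units; within the scatter) from compound 3 to compound 4, 1.5-fold (0.18 log units) apart, within the scatter of two such steps. So nothing here separates how the two cores respond, and on neither core is the step beyond the scatter, but this does not show that the change carries over reliably, for two steps this small would look alike whether or not the cores respond in the same way.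

The compounds shown leave open whether a longer chain than butyl, or an amine or a carboxylic acid in its place, would give a step large enough to compare across the two cores. Only a step beyond the scatter on one core, repeated on the other, would test whether a change truly carries from one core to the other.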